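Replacing the Sulfonamide Cap: Oxazole Gives Way to Pyridine

The source may hold more compounds than are shown below. What is called first, only, known or untested is meant among the compounds shown, and "the series" means these compounds.

Measured so far:
Compound 1, `CC(=O)NS(=O)(=O)c1ccc(N/C(S)=N\c2ccnc3cc(C(F)(F)F)ccc23)cc1`, 28400 nM
Compound 2, `Cc1cc(NS(=O)(=O)c2ccc(N/C(S)=N\c3ccnc4cc(C(F)(F)F)ccc34)cc2)on1`, 28500 nM

In a functional assay on HepG2 cells (Homo sapiens) for antiproliferative activity, read by sulforhodamine B assay, with a stated time of 48 h (on this read-out higher numbers stand for weaker inhibition and lower numbers for stronger inhibition), compound 1 gives 28400 nM, and in this assay compound 2 gives 28500 nM. Among the measured compounds shown here, the two numbers lie within the usual scatter of each other, so compound 2 cannot be set apart from compound 1; the one step that connects them, a 1.0-fold higher number from compound 1 to compound 2 (0.00 log units; within the scatter), is flat.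

Compound 3, `O=S(=O)(Nc1ccccn1)c1ccc(N/C(S)=N\c2ccnc3cc(C(F)(F)F)ccc23)cc1`, is still to be measured in this assay. It differs from compound 2 in one place: pyridin-2-yl in place of 3-methyl-1,2-oxazol-5-yl on a sulfonamide nitrogen.

For the measured compounds named here, the only step that bears on this change is the earlier one on the same sulfonamide nitrogen, a 1.0-fold higher number from compound 1 to compound 2 (0.00 log units; within the scatter), in which an acetyl group gave way to the 3-methyl-1,2-oxazol-5-yl group with no shift beyond the scatter. Because that step a 1.0-fold higher number from compound 1 to compound 2 (0.00 log units; within the scatter) showed no effect of exchanging the group on this nitrogen, the further exchange to pyridin-2-yl is expected to leave the number where it is, with no step beyond the scatter in either direction.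

Compound 3 is therefore estimated at 28000 nM, in a range from 14000 nM to 60000 nM. The expected step is a 1.0-fold lower number from compound 2 to compound 3 (0.01 log units; within the scatter).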

Compound 3, half-maximal inhibitory concentration: 28000 nM
Beside the measured number, compound 3's estimate shows no gap at the digits printed; the range from low to high includes it.
By their numbers in this assay, from the lowest: compounds 3, 1 and 2 (each within the scatter of the next).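

In this assay, the exchange of the five-membered 3-methyl-1,2-oxazol-5-yl ring for the six-membered pyridin-2-yl ring on the sulfonamide nitrogen gives a 1.0-fold lower number from compound 2 to compound 3 (0.01 log units; within the scatter), a comparison between two aromatic rings that the earlier pair, with its acetyl group, did not offer. Set directly against acetyl, pyridin-2-yl gives a 1.0-fold lower number from compound 1 to compound 3 (0.01 log units; within the scatter), so a second aromatic ring now matches the acetyl group within the scatter, and the three groups on this nitrogen cannot be told apart in this read-out. No measurement at hand explains why the number stays flat across these groups.

On these data alone, whether the flat picture holds for groups of another kind on this nitrogen, such as a carboxylic acid, an amine or a longer alkyl chain, stays open, as does the plain sulfonamide with hydrogen in that place. All three compounds also share the same core, so the compounds shown do not say whether a change elsewhere in the structure would move the number beyond the scatter.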